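The source may hold more compounds than are shown below. What is called first, only, known or untested is meant among the compounds shown, and "the series" means these compounds.

In a functional assay on DU-145 cells (Homo sapiens) for inhibition, read by CCK-8 assay, with a stated time of 72 h (a lower number here means a stronger inhibitor, a higher number a weaker inhibitor), compound 1 (`O=C(/C=C/c1cccnc1)NCCCCCc1cccc(S(=O)(=O)Nc2ccccc2)c1`) gives 140 nM, while compound 2 (`O=C(/C=C/c1cccnc1)NCCCCCCc1cccc(S(=O)(=O)Nc2ccccc2)c1`) gives 6.73 nM, the lower of the two numbers by a gap beyond the usual scatter. Compound 3 (`CC(C)(C)c1ccc(NS(=O)(=O)c2cccc(CCCCCCNC(=O)/C=C/c3cccnc3)c2)cc1`) departs from compound 2 in one place, with tert-butyl in place of hydrogen on an aromatic carbon, turning phenyl to 4-(tert-butyl)phenyl: tert-butyl in place of hydrogen on an aromatic carbon. For the measured compounds named here, no measured pair in this small set shows what a substituent at that place does in this assay. The direction and size of the change therefore remain a matter of expectation. A small rise in the number is expected, one that may not pass the scatter, and the estimated change is a 1.8-fold higher number from compound 2 to compound 3 (0.25 log units; within the scatter). The measurement for compound 3 is expected at 12 nM, with an estimated range from 2 nM to 70 nM.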

Compound 3, half-maximal inhibitory concentration: 281 nM
For compound 3 the middle estimate is 23-fold (1.37 log units) below the measured one; the whole stated range lies below it.
By their numbers in this assay, from the lowest: compound 2; then compounds 1 and 3 (each within the scatter of the next).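

In this assay tert-butyl in place of hydrogen on this aromatic carbon, para to a large group, gives a 42-fold higher number from compound 2 to compound 3 (1.62 log units; beyond the scatter) and so makes compound 3 a much weaker inhibitor. For the compounds shown here, this is the first reading of a substituent at this place, and it shows that the phenyl of compound 2 does not accept every group there: one branched group of four carbons is enough to lose most of the strength of compound 2. No measurement shown here explains this loss.

The compounds shown leave open whether a smaller group, such as methyl or a fluorine atom, would be tolerated on the same carbon. They also leave open how an amine or a carboxylic acid would behave there, and whether tert-butyl would have the same effect on another carbon of the ring.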